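Bromo-for-hydrogen on the furan of an acrylamide

This account rests on a few compounds, and the source may have more. Where it says the series, first, only, none or still open, it means among the compounds named here.

Measured so far:
- compound 1, `N#C/C(=C\c1ccc([N+](=O)[O-])cc1)C(=O)c1c[nH]c2ccccc12`: 60000 nM
- compound 2, `N#C/C(=C\c1c(F)c(F)c(F)c(F)c1F)C(=O)c1c[nH]c2ccccc12`: 20000 nM
- compound 3, `COc1ccc(CNC(=O)/C(C#N)=C/c2ccco2)cc1`: 33000 nM

All three were run in a functional assay on SMA cells (Homo sapiens) for inhibition, read by MTT assay, with a stated time of 72 h; a lower number here means a stronger inhibitor of growth, a higher number a weaker inhibitor of growth. Compound 1 gives 60000 nM and compound 2 gives 20000 nM, both with the shared core of compound 1. Compound 3, with an amide instead, gives 33000 nM; its number falls between the other two, yet the gap to compound 2 and the gap to compound 1 both lie within the scatter of this assay, so no order among the three can be read from these values.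

The unmeasured compound 4, `COc1ccc(CNC(=O)/C(C#N)=C/c2ccc(Br)o2)cc1`, differs from compound 3 in one place: bromo in place of hydrogen on an aromatic carbon. The change sits on an aromatic carbon of a five-membered aromatic ring with one oxygen, next to the ring oxygen; read one bond further out it is furan-2-yl to 5-bromofuran-2-yl. Within the data shown here, no pair of measured compounds shows what such a change does in this assay, so nothing here fixes its size or direction.

The expectation for compound 4 is therefore a step no larger than the scatter, a 1.7-fold lower number from compound 3 to compound 4 (0.22 log units; within the scatter), with a slight lean towards a lower number. Compound 4 is estimated at 20000 nM, in the range 7000 nM to 60000 nM.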

Compound 4, concentration for 50% growth inhibition: 14000 nM
Compound 4: the middle estimate sits 1.4-fold (0.15 log units) above what was measured; the measured number falls inside the stated range.
By their numbers in this assay, from the lowest: compounds 4, 2, 3 and 1 (each within the scatter of the next, the first and the last beyond it).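

In this assay, among these compounds, furan-2-yl to 5-bromofuran-2-yl gives a 2.4-fold lower number from compound 3 to compound 4 (0.37 log units; beyond the scatter), the first step that can be tied to one change in one place. It shows that this aromatic carbon, next to the ring oxygen and two ring bonds from the ring atom that bears a large group, is not indifferent to substitution: adding one bromine moves the number towards stronger inhibition of growth, and a bromo group is accepted here without loss. Nothing available explains this step, and its size and direction rest on this single pair of compounds.

On these data alone, whether the step belongs to bromine in particular or to any group on this carbon remains open, and chloro, methyl, methoxy, an amine or a carboxylic acid at the same place would help to separate those readings. Among the compounds shown here, also open is whether the same change gives a step of similar size and direction on the shared core of compound 1, where no pair yet speaks to it.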